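The compounds below may be only part of what the source reports. "The series", "measured", "known", "first", "only" and "open" are said of these compounds alone.

Of the compounds shown here, three of a shared core have been measured in an assay on cell membranes for binding affinity to adenosine receptor A1 (Cavia porcellus), read by radioligand binding; on this read-out lower numbers stand for stronger inhibition and higher numbers for weaker inhibition. Compound 1 `CCCn1c(=O)c2nc(C(O)(CC)CC)[nH]c2n(CCC)c1=O` carries a 1-ethyl-1-hydroxypropyl group and gives 170 nM. Compound 2 `CCCn1c(=O)c2nc(-c3nn[nH]n3)[nH]c2n(CCC)c1=O` carries a 2H-tetrazol-5-yl group, and in this assay compound 2 reaches only the limit > 10000 nM, which is not a number (the limit of > 10000 nM in this assay, at which 1 of the 3 values shown sits). Compound 3 `CCCn1c(=O)c2nc(-c3ccco3)[nH]c2n(CCC)c1=O` carries a furan-2-yl group and gives 560 nM, the highest of the two numbers, with compound 1 nearest a 3.3-fold higher number from compound 1 to compound 3 (0.52 log units; beyond the scatter). The step from compound 2 to compound 3 was large an at least 17-fold lower number from compound 2 to compound 3 (1.25 log units; beyond the scatter).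

Compound 4 `CCCn1c(=O)c2nc(CC(C)(C)C)[nH]c2n(CCC)c1=O` has not yet been measured. It differs from compound 3 in one place (neopentyl in place of furan-2-yl on an aromatic carbon). The step from compound 1 to compound 3, which removed a branched, hydroxyl-bearing chain in favour of the furan, was modest a 3.3-fold higher number from compound 1 to compound 3 (0.52 log units; beyond the scatter); the reverse change toward a branched chain, now without the hydroxyl, is the closest guide. A modest step downward is therefore expected a 2.5-fold lower number from compound 3 to compound 4 (0.41 log units; beyond the scatter), but not beyond the range spanned by compound 1 and compound 3. For compound 4 the estimate in this assay is 220 nM, expected to lie between 60 nM and 800 nM.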

Compound 4, inhibition constant: 49 nM
For compound 4 the middle estimate is 4.5-fold (0.65 log units) above the measured one; measured number below the stated range.
By their numbers in this assay, from the lowest: compound 4; then compound 1; then compound 3. At a limit, above all of these: compound 2.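

Replacing furan-2-yl with neopentyl, which has the same count of heavy atoms, gives an 11-fold lower number from compound 3 to compound 4 (1.06 log units; beyond the scatter) in this assay, so a ring is not needed at this position, on an aromatic carbon between two ring nitrogen atoms. Neopentyl also improves on the hydroxyl-bearing chain, with a 3.5-fold lower number from compound 1 to compound 4 (0.54 log units; beyond the scatter), so a hydroxyl is not needed here either. Compound 2 stands at a limit and not at a number, and the step to neopentyl is an at least 200-fold lower number from compound 2 to compound 4 (2.30 log units; beyond the scatter): the limit of > 10000 nM in this assay, at which 1 of the 4 values shown sits.

Still open, as far as these compounds go, is whether the branching of neopentyl counts, which a straight pentyl chain at the same place would test. Equally open, from the compounds shown here alone, is whether a saturated ring such as cyclopentyl would behave more like neopentyl or more like furan-2-yl.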